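The source may report more compounds than this note shows. Statements on the series, on what has been measured and on what is new or still open speak of the compounds shown alone.

Measured in a functional assay on OVCAR-3 cells (Homo sapiens) for inhibition, read by sulforhodamine B assay, with a stated time of 48 h; on this read-out lower numbers stand for stronger inhibition of growth and higher numbers for weaker inhibition of growth:
compound 1 `O=C(Cc1csc2nc(-c3ccc(Br)cc3)cn12)N/N=C/c1ccccc1`: 24000 nM
compound 2 `O=C(Cc1csc2nc(-c3ccc(Br)cc3)cn12)N/N=C/c1ccccc1O`: 3240 nM
compound 3 `O=C(Cc1csc2nc(-c3ccc(Br)cc3)cn12)N/N=C/c1ccc(O)cc1`: 24000 nM

Compound 3 stands level with compound 1, and together they hold the highest of the three numbers. Compound 4 `COc1cccc(OC)c1/C=N/NC(=O)Cc1csc2nc(-c3ccc(Br)cc3)cn12` carries 2,6-dimethoxyphenyl in place of 4-hydroxyphenyl on a carbon with a double bond to nitrogen. Within the data shown here, three measured steps bear on this change: no change at the digits printed from compound 1 to compound 3 (within the scatter), a 7.4-fold lower number from compound 1 to compound 2 (0.87 log units; beyond the scatter) and a 7.4-fold higher number from compound 2 to compound 3 (0.87 log units; beyond the scatter). Among the measured compounds shown here, the aryl group therefore can matter, but no measured compound carries 2,6-dimethoxyphenyl, so these steps guide only loosely. The expected move in this assay is small, toward a lower number if any, and the estimate amounts to a 1.7-fold lower number from compound 3 to compound 4 (0.23 log units; within the scatter). Compound 4 is expected at 14000 nM, within an estimated range of 3500 nM to 40000 nM.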

Compound 4, concentration for 50% growth inhibition: 15800 nM
The estimate for compound 4 lay 1.1-fold (0.05 log units) below the measured number, and the stated range covers the measured number.
By their numbers in this assay, from the lowest: compound 2; then compounds 4, 1 and 3 (each within the scatter of the next).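

In this assay, 2,6-dimethoxyphenyl on this carbon gives no separation from phenyl (a 1.5-fold lower number from compound 1 to compound 4 (0.18 log units; within the scatter)) or from 4-hydroxyphenyl (a 1.5-fold lower number from compound 3 to compound 4 (0.18 log units; within the scatter)). Compound 2 remains apart from this new group as well (a 4.9-fold higher number from compound 2 to compound 4 (0.69 log units; beyond the scatter)), so among these four compounds, only compound 2, with its 2-hydroxyphenyl, stands beyond the scatter of the others. No measurement shown here accounts for this separation. Still open, going by these compounds, is whether compound 2 would keep its number with an amine or a single methoxy group in place of its hydroxy.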